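This account rests on a few compounds, and the source may have more. Where it says the series, first, only, none or still open, it means among the compounds named here.

Measured compounds:
compound 1 `O=C(Nc1cccc(-n2cc(-c3ccncc3)c(-c3cc(O)cc(Cl)c3)n2)c1)Nc1ccc(Cl)c(C(F)(F)F)c1` with -18%
compound 2 `COc1cc(Cl)cc(-c2nn(-c3cccc(NC(=O)Nc4ccc(Cl)c(C(F)(F)F)c4)c3)cc2-c2ccncc2)c1` with -9.68%

In a functional assay on MOLT-4 cells (Homo sapiens) for inhibition, read by sulforhodamine B assay, with a stated time of 48 h, tested at 10 uM (on this read-out lower numbers stand for a stronger effect and higher numbers for a weaker effect at the one concentration tested), compound 1 gives -18% and compound 2 gives -9.68%. For the measured compounds named here, the one step available, a number 8.3 percentage points higher from compound 1 to compound 2 (within the scatter), comes from putting methyl in place of hydrogen on an oxygen on an aromatic ring. Compound 2 therefore holds the higher of the two numbers, but its gap to compound 1 is within the scatter, so the two compounds cannot be told apart on this assay.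

Compound 3 `COc1cc(Cl)cc(-c2nn(-c3cccc(NC(=O)c4cccc(C(F)(F)F)c4)c3)cc2-c2ccncc2)c1` is the next compound. It differs from compound 2 in one place: 3-(trifluoromethyl)phenyl in place of (4-chloro-3-(trifluoromethyl)phenyl)amino on a carbonyl carbon. Going by the values given here, no measured step touches this part of the shared core; the only step known changes the oxygen substituent on the other aromatic ring and is itself within the scatter. There is thus nothing in the data that would predict a shift of any size or direction from this change, and the two measured numbers cluster close together.

Compound 3 is accordingly expected to stay near compound 2, with an expected step of a number 4.7 percentage points higher from compound 2 to compound 3 (within the scatter). The estimate for compound 3 in this assay is -5%, in a range from -25% to 20%.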

Compound 3, a percentage reported as activity, at one concentration (the size of the read-out at that concentration, not a potency): 29%
The estimate for compound 3 lay 34 percentage points below the measured number; the whole stated range lies below it.
By their numbers in this assay, from the lowest: compounds 1 and 2 (each within the scatter of the next); then compound 3.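

For the compounds shown here, the position on the carbonyl carbon is the one place in these compounds where a change moves the read-out beyond the scatter: in this assay the swap gives a number 38.7 percentage points higher from compound 2 to compound 3 (beyond the scatter), a large step towards a weaker effect at the one concentration tested, while the change on the oxygen gave only a number 8.3 percentage points higher from compound 1 to compound 2 (within the scatter). The swap alters more than one feature at once, since the group that leaves holds the amino nitrogen, a hydrogen-bond donor and the chlorine, and the 3-(trifluoromethyl)phenyl group that enters has none of these, so the step belongs to the whole exchange and not to any single one of them. Nothing measured here explains the loss of effect.

The compounds shown leave open whether the step follows the nitrogen or the chlorine: a (3-(trifluoromethyl)phenyl)amino group or a 4-chloro-3-(trifluoromethyl)phenyl group on the same carbonyl carbon would keep one without the other. As far as these compounds go, it also remains open whether the same exchange would carry a similar step with the hydroxy group of compound 1 in place of the methoxy group.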